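Moving the Methyl Group Around the Oxadiazole Ring

The source may hold more compounds than are shown below. What is called first, only, known or untested is meant among the compounds shown, and "the series" means these compounds.

Compound 1 `Cc1coc(Cn2nc3ccc(-c4ccc(OC(F)(F)F)cc4)cn3c2=O)n1`: 2.67 h
Compound 2 `Cc1noc(Cn2nc3ccc(-c4ccc(Oc5ccc(F)cc5)cc4)cn3c2=O)n1`: 3.62 h
Compound 3 `Cc1cnc(Cn2nc3ccc(-c4ccc(OC(F)(F)F)cc4)cn3c2=O)o1`: 3.8 h
Compound 4 `Cc1nc(Cn2nc3ccc(-c4ccc(Oc5ccc(F)cc5)cc4)cn3c2=O)no1`: not yet measured

In an ADME assay on microsomes (Canis lupus familiaris) for metabolic stability (a higher number here means that the compound lasts longer, a lower number that the compound disappears faster), compound 2 gives 3.62 h, a number within the scatter of the values for both other measured compounds. The change that leads to compound 4 is 5-methyl-1,2,4-oxadiazol-3-yl in place of 3-methyl-1,2,4-oxadiazol-5-yl on a saturated chain carbon bound to an aromatic nitrogen. Here, 5-methyl-1,2,4-oxadiazol-3-yl takes the place of 3-methyl-1,2,4-oxadiazol-5-yl on a saturated chain carbon bound to an aromatic nitrogen. Among the measured compounds shown here, no measured pair contains this exact exchange. The closest comparison is the exchange of 4-methyl-1,3-oxazol-2-yl for 5-methyl-1,3-oxazol-2-yl at the same place, which gave a 1.4-fold higher number from compound 1 to compound 3 (0.15 log units; within the scatter). That single step stayed within the scatter, but it involves a different ring in a different compound series, so it is only limited evidence. No step beyond the scatter is therefore expected in this assay, and the data suggest no direction. The expected change is a 1.1-fold lower number from compound 2 to compound 4 (0.03 log units; within the scatter). Compound 4 is estimated at 3.4 h, with an expected range from 1.8 h to 6.3 h.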

Compound 4, half-life: 2.78 h
Compound 4: the middle estimate sits 1.2-fold (0.09 log units) above what was measured, within the range that was stated.
By their numbers in this assay, from the lowest: compounds 1, 4, 2 and 3 (each within the scatter of the next).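

In this assay, going from the 3-methyl-1,2,4-oxadiazol-5-yl group to the 5-methyl-1,2,4-oxadiazol-3-yl group on the saturated chain carbon gave a 1.3-fold lower number from compound 2 to compound 4 (0.11 log units; within the scatter), even though the two groups hold the same atoms. With a 1.4-fold higher number from compound 1 to compound 3 (0.15 log units; within the scatter), the methyl oxazole pair, this place now has two such rearrangements, one in each of two series, and neither step leaves the scatter; no compound shown goes against this. Nothing measured here explains this result.

The compounds shown leave open whether a different kind of group at this place, such as an amine or a carboxylic acid, or a longer chain would give a step beyond the scatter. They also leave open whether the oxadiazole exchange would read the same on the core of compound 1.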